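Swapping 4-bromobenzyl for 3-cyanobenzyl: working notes

The source may hold more compounds than are shown below. What is called first, only, known or untested is meant among the compounds shown, and "the series" means these compounds.

The series is followed in a functional assay on a cell-free system (plasma, Oryctolagus cuniculus) for inhibition, with stated times of 5 min, 1 min and 6 min; on this read-out higher numbers stand for weaker inhibition and lower numbers for stronger inhibition. Compound 1 `CCOCCOn1c(-c2cccc(C#N)c2)nc(C)c1C(=O)OCC`, with ethoxymethyl on a saturated chain carbon bound to an oxygen on an aromatic ring, gives 6250 nM. At the same place, compound 2 `CCOC(=O)c1c(C)nc(-c2cccc(C#N)c2)n1OCc1cccc(F)c1` carries 3-fluorophenyl and gives 22400 nM. Compound 3 `CCOC(=O)c1c(C)nc(-c2cccc(C#N)c2)n1OCc1ccc(Br)cc1` carries 4-bromophenyl and gives 24600 nM. Compound 3 therefore stands level with compound 2 at the weak end of the three numbers, and both lie on the weaker side of compound 1.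

Compound 4 `CCOC(=O)c1c(C)nc(-c2cccc(C#N)c2)n1OCc1cccc(C#N)c1` is not yet measured. The change is 3-cyanophenyl in place of 4-bromophenyl on a saturated chain carbon bound to an oxygen on an aromatic ring.

Replacing ethoxymethyl with an aromatic group gave modest steps beyond the scatter: a 3.6-fold higher number from compound 1 to compound 2 (0.55 log units; beyond the scatter) and a 3.9-fold higher number from compound 1 to compound 3 (0.60 log units; beyond the scatter). The closer precedent is the exchange of one substituted phenyl for another, a 1.1-fold higher number from compound 2 to compound 3 (0.04 log units; within the scatter), which stays within the scatter. It is a single pair, and 3-cyanophenyl itself has no measurement at this place.

No step beyond the scatter is therefore expected, and the estimated step is a 1.1-fold lower number from compound 3 to compound 4 (0.05 log units; within the scatter). The estimate for compound 4 is 22000 nM, with an expected range of 10000 nM to 48000 nM.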

Compound 4, half-maximal inhibitory concentration: > 30000 nM
Compound 4: no number, only a limit; the forecaster's own chance of this, stated with the estimate: 10%; middle value at least 1.3-fold (0.13 log units) from the limit.
By their numbers in this assay, from the lowest: compound 1; then compounds 2 and 3 (each within the scatter of the next). At a limit, above all of these: compound 4.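

In this assay, compound 4 gives no number, only a limit: the limit of > 30000 nM in this assay, at which 1 of the 4 values shown sits.

Against the two other aromatic groups the step can be read only as a floor, an at least 1.2-fold higher number from compound 3 to compound 4 (0.08 log units; that floor lies within the scatter) and an at least 1.3-fold higher number from compound 2 to compound 4 (0.12 log units; that floor lies within the scatter), so this result does not set 3-cyanophenyl apart from 4-bromophenyl or from 3-fluorophenyl at this place. What is new lies in the comparison with the ethoxymethyl compound, an at least 4.8-fold higher number from compound 1 to compound 4 (0.68 log units; beyond the scatter): a third substituted phenyl, now one carrying a nitrile, also falls on the weaker side, and among the compounds shown no aromatic group at this place goes against that trend.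

The limit leaves open how large the exchange of 4-bromobenzyl for 3-cyanobenzyl really is, and so whether the nitrile changes inhibition at all relative to the halogen-bearing rings. The compounds shown also leave open whether the stronger inhibition of compound 1 goes with its ether oxygen or simply with the lack of a phenyl ring at this place, which a plain propyl or butyl chain, or a chain ending in an amine or a carboxylic acid, would help to separate.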